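Swapping a Nitrile for Bromine on the Outer Ring

The source may report more compounds than this note shows. Statements on the series, on what has been measured and on what is new or still open speak of the compounds shown alone.

Measured compounds:
compound 1, `N#Cc1cccc(-n2cc(COc3cccc(NC(=O)Nc4ccc(Cl)c(C(F)(F)F)c4)c3)nn2)c1`: 2960 nM
compound 2, `CC(C)c1cccc(-n2cc(COc3cccc(NC(=O)Nc4ccc(Cl)c(C(F)(F)F)c4)c3)nn2)c1`: 21400 nM

Two compounds share a common core and differ only in one group on an aromatic carbon of a six-membered aromatic ring of carbon only. In a toxicity assay on MRC5 cells (Homo sapiens) for inhibition, read by MTT assay, with a stated time of 72 h (on this read-out lower numbers stand for stronger inhibition and higher numbers for weaker inhibition), compound 1 gives 2960 nM, the lowest of the two numbers shown, while compound 2 gives 21400 nM. Among the compounds with values here, the one measured step, a 7.2-fold higher number from compound 1 to compound 2 (0.86 log units; beyond the scatter), shows that replacing the nitrile with a larger isopropyl group weakens the effect on these cells.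

Compound 3, `O=C(Nc1cccc(OCc2cn(-c3cccc(Br)c3)nn2)c1)Nc1ccc(Cl)c(C(F)(F)F)c1`, carries instead a bromine at that same carbon: bromo in place of cyano on an aromatic carbon. Within the data shown here, no step with a bromine has been measured, so only the isopropyl step gives a hint of direction. Bromine is a single heavy atom, smaller than isopropyl, so the change is expected to move the number in the same direction as a 7.2-fold higher number from compound 1 to compound 2 (0.86 log units; beyond the scatter) but less far. The estimated step is a 2.0-fold higher number from compound 1 to compound 3 (0.31 log units; beyond the scatter). Compound 3 is therefore expected to give about 6000 nM in this assay, within a range of 2500 nM to 15000 nM.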

Compound 3, half-maximal inhibitory concentration: 11900 nM
Beside the measured number, compound 3's estimate is 2.0-fold (0.30 log units) below it; measured number inside the range.
By their numbers in this assay, from the lowest: compound 1; then compounds 3 and 2 (each within the scatter of the next).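

In this assay, the nitrile has now been replaced by two different groups at this carbon, and both replacements move the number up. Bromo in place of cyano gives a 4.0-fold higher number from compound 1 to compound 3 (0.60 log units; beyond the scatter) and shows that this rise does not depend on a group as large as isopropyl, since the bromo group is a single heavy atom. The two replacements cannot be told apart here, as the comparison between them reads a 1.8-fold lower number from compound 2 to compound 3 (0.25 log units; within the scatter) and leaves compound 1 as the only one of the three set clearly apart, though nothing available here explains what sets the nitrile apart.

The compounds shown leave open how quite different groups at this carbon would read, such as an amine, a carboxylic acid or a longer chain, and whether any of them would bring the number down to that of compound 1 or lower. They also leave open whether the nitrile would keep its place among these groups on another carbon of the same ring, or with a different group elsewhere on the shared core.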